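The source may hold more compounds than are shown below. What is called first, only, known or untested is meant among the compounds shown, and "the series" means these compounds.

Measured so far: compound 1 `COc1ccc(S(=O)(=O)Nc2cc(Br)cc(Br)c2)cc1N1CCNCC1` gives 0.501 nM in an assay on isolated protein for binding affinity to 5-hydroxytryptamine receptor 6 (Homo sapiens); on this read-out lower numbers stand for stronger inhibition and higher numbers for weaker inhibition; compound 2 `COc1ccc(S(=O)(=O)Nc2cc(Cl)cc(Cl)c2Br)cc1N1CCNCC1` gives 3.16 nM in this assay.

Compound 2 shows the highest of the two numbers, with compound 1 standing at a lower number by a 6.3-fold higher number from compound 1 to compound 2 (0.80 log units; beyond the scatter). Compound 3 `COc1ccc(S(=O)(=O)Nc2cc(Cl)cc(Br)c2Cl)cc1N1CCNCC1` keeps every atom of compound 2 and changes only their arrangement: 3-bromo-2,5-dichlorophenyl in place of 2-bromo-3,5-dichlorophenyl on a sulfonamide nitrogen. Among the measured compounds shown here, the only step available, from compound 1 to compound 2, moved the number by a 6.3-fold higher number from compound 1 to compound 2 (0.80 log units; beyond the scatter), but it swapped atoms rather than rearranging them, so it bears on this step only loosely. Compound 3 is therefore expected to stay near compound 2, with a step of about a 1.3-fold lower number from compound 2 to compound 3 (0.10 log units; within the scatter) in this assay, within or barely beyond the scatter. The estimate for compound 3 is 2.5 nM, ranging from 0.8 nM to 8 nM.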

Compound 3, inhibition constant: 2 nM
Compound 3: the middle estimate sits 1.3-fold (0.10 log units) above what was measured; the range from low to high includes it.
By their numbers in this assay, from the lowest: compound 1; then compounds 3 and 2 (each within the scatter of the next).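

Rearranging the same atoms, with 3-bromo-2,5-dichlorophenyl in place of 2-bromo-3,5-dichlorophenyl on the sulfonamide nitrogen, gives a 1.6-fold lower number from compound 2 to compound 3 (0.20 log units; within the scatter) in this assay, so these two arrangements cannot be told apart. The 3,5-dibromophenyl of compound 1 still gives the lowest number, and the swap to compound 3 shows a 4.0-fold higher number from compound 1 to compound 3 (0.60 log units; beyond the scatter) as a step beyond the scatter. No measured evidence here accounts for these numbers.

Still open, going by these compounds, is whether the phenyl group needs its halogens at all, and how an amine or a nitrile in place of the bromine would read.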